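A few compounds are considered here, and "the series" means these few. Any claim that something is new, unique, unknown or untested is made for them only; others in the source may bear on it.

Measured so far in a functional assay on cells for agonist activity at C-X-C chemokine receptor type 4 (Homo sapiens), read by fluorescence and calcium flux, with a stated time of 90 s; on this read-out lower numbers stand for an effect already at smaller amounts and higher numbers for an effect only at larger amounts of compound:
compound 1 `c1ccc2c(c1)CN[C@@H](CN(CCCCNCc1ccncc1)[C@H]1CCCc3cccnc31)C2`, > 30000 nM
compound 2 `c1ccc2c(c1)CN[C@@H](CN(CCCCNCC1CCNCC1)[C@H]1CCCc3cccnc31)C2`, > 30000 nM
compound 3 `c1ccc2c(c1)CN[C@@H](CN(CCCCNC1CCSCC1)[C@H]1CCCc3cccnc31)C2`, > 30000 nM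

Each of these values is a limit of the assay, not a number. All three sit at the limit of > 30000 nM in this assay, at which 3 of the 3 values shown sit. Compound 3 thus stands at the limit, with no number to place it against the others. The steps between the measured compounds are unreadable for the same reason: a step that the two limits leave unreadable from compound 1 to compound 2, a step that the two limits leave unreadable from compound 1 to compound 3, a step that the two limits leave unreadable from compound 2 to compound 3.

Compound 4 `CC(C)(CN)CCN(C[C@H]1Cc2ccccc2CN1)[C@H]1CCCc2cccnc21` differs from compound 3 by a group of 5 heavy atoms (4 carbon, 1 nitrogen; no ring) in place of a group of 9 heavy atoms (7 carbon, 1 nitrogen, 1 sulfur; one six-membered non-aromatic ring with 1 hetero atom), on a saturated chain carbon, two bonds along the chain from an amine nitrogen. The measured steps bear on it only in that every change at this end of the chain has so far left the value at the limit; no size can be carried over. The step is expected to be a number no higher from compound 3 to compound 4 (the limit leaves the size open). Compound 4 is therefore estimated at 30000 nM, range 8000 nM to 100000 nM, most likely reported again as a limit.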

Compound 4, half-maximal effective concentration: > 30000 nM
Compound 4 ended at the assay's limit; the forecaster's own chance of this, stated with the estimate: 80%; the middle value sits exactly at the limit.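

Going by these compounds alone, compound 4 gives > 30000 nM as a limit and not a number, so no step from it to compound 1, compound 2 or compound 3 can be read. The compounds shown leave open which change at this end of the chain, if any, would give a measurable value.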